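A few compounds are considered here, and "the series" means these few. Any claim that something is new, unique, unknown or untested is made for them only; others in the source may bear on it.

Working notes on the sulfur substituent in a functional assay on PC-9 cells (Homo sapiens) for antiproliferative activity, read by MTT assay; on this read-out higher numbers stand for weaker inhibition and lower numbers for stronger inhibition. Compound 1 (`C#CCSc1nc(Sc2ccccn2)c(C#N)c(-c2cc(OC)c(OC)c(OC)c2)n1`) gives > 20000 nM, which is a limit and not a number. Compound 2 (`C#CCSc1nc(Sc2nc[nH]n2)c(C#N)c(-c2cc(OC)c(OC)c(OC)c2)n1`) gives > 20000 nM, also a limit, so it has no exact place on the scale. The evidence so far is the limit of > 20000 nM in this assay, at which 2 of the 2 values shown sit.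

Compound 3 (`C#CCSc1nc(Sc2nc3ccccc3s2)c(C#N)c(-c2cc(OC)c(OC)c(OC)c2)n1`) follows from compound 2 by 1,3-benzothiazol-2-yl in place of 1H-1,2,4-triazol-3-yl on a sulfur. In words, 1,3-benzothiazol-2-yl stands in place of 1H-1,2,4-triazol-3-yl on a sulfur.

Going by the values given here, the one measured step at this place is a step that the two limits leave unreadable from compound 1 to compound 2, and it has no readable size. On that step, no shift beyond the scatter can be expected in this assay, and no direction can be assigned. An estimated a number no higher from compound 2 to compound 3 (the limit leaves the size open) is therefore expected. For compound 3 the expected value is 20000 nM, with an estimated range of 7000 nM to 40000 nM.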

Compound 3, half-maximal inhibitory concentration: > 20000 nM
Compound 3 ended at the assay's limit (the forecaster's own chance of this, stated with the estimate: 70%); the middle value lies on the limit itself.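

No new step can be read: in this assay, compound 3 sits at a limit, as do compound 1 and compound 2, so its steps from both compare limits, not numbers. The compounds shown leave open how the three sulfur substituents rank, with all resting on one limit: the limit of > 20000 nM in this assay, at which 3 of the 3 values shown sit.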